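Swapping Cyano for Trifluoromethyl: Stability Outlook for Compound 4

The compounds below may be only part of what the source reports. "The series", "measured", "known", "first", "only" and "open" are said of these compounds alone.

Measured compounds in an ADME assay on microsomes from liver (Canis lupus familiaris) for metabolic stability; a lower number here means that the compound disappears faster, a higher number that the compound lasts longer:
Compound 1 `N#Cc1ccc(-c2nc(NCCNc3ccc([N+](=O)[O-])c(N)n3)ncc2-c2ncc[nH]2)cc1` gives > 0.5 h, a limit of the assay rather than a number.
Compound 2 `N#Cc1ccc(NCCNc2ncc(-c3ncc[nH]3)c(-c3ccc(Cl)cc3Cl)n2)nc1` gives > 0.5 h, also a limit.
Compound 3 `FC(F)(F)c1ccc(NCCNc2ncc(-c3ncc[nH]3)c(-c3ccc(Cl)cc3Cl)n2)nc1` gives > 0.5 h, again a limit.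

Compound 1 thus stands only at a limit of this assay, as do the other two compounds shown (the limit of > 0.5 h in this assay, at which 3 of the 3 values shown sit). Compound 4 `Nc1nc(NCCNc2ncc(-c3ncc[nH]3)c(-c3ccc(C(F)(F)F)cc3)n2)ccc1[N+](=O)[O-]` differs from compound 1 in one place: trifluoromethyl in place of cyano on an aromatic carbon. Among the measured compounds shown here, the one measured step with the same change is a step that the two limits leave unreadable from compound 2 to compound 3, which gives no readable size. With every value at the limit, no step beyond the scatter can be expected in this assay, in either direction. The expected step is a step that the limit leaves unreadable from compound 1 to compound 4. Compound 4 is therefore estimated at 1 h, within 0.5 h to 3 h, and most likely reported again as a limit.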

Compound 4, half-life: > 0.5 h
Compound 4 ended at the assay's limit; the forecaster's own chance of this, stated with the estimate: 75%; the middle value does not contradict the limit.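

The step between compound 1 and compound 4 cannot be read, since both values are limits in this assay: the limit of > 0.5 h in this assay, at which 4 of the 4 values shown sit.

The compounds shown leave open how long each one actually lasts, and whether trifluoromethyl in place of cyano changes that at all.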